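Trimming the amine of a sigma-1 ligand to a primary amine

This account rests on a few compounds, and the source may have more. Where it says the series, first, only, none or still open, it means among the compounds named here.

The compounds share one core, a phenyl-bearing saturated ring with a two-carbon chain ending in a nitrogen. Compound 1 `CN(C)CC[C@H]1CCC[C@@H](c2ccccc2)C1` gives 10 nM in an assay on membranes from brain for displacement of a labelled ligand from Sigma non-opioid intracellular receptor 1 (Cavia porcellus), read by scintillation counting, with a stated time of 120 min; on this read-out higher numbers stand for weaker inhibition and lower numbers for stronger inhibition. Compound 2 `c1ccc(CNCC[C@@H]2CCC[C@@H](c3ccccc3)C2)cc1` gives 1.8 nM; 2.4 nM (2 entries) in this assay, and the several entries of compound 2 in this assay, 1.8 nM; 2.4 nM (2 entries) shows its repeats lie close together. Compound 3 `c1ccc([C@H]2CCC[C@@H](CCN3CCCC3)C2)cc1` gives 3.6 nM in this assay, the lowest of the two single numbers shown; compound 1 stands higher by a margin beyond the scatter, and compound 2 has no single number.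

Compound 4 `NCC[C@@H]1CCC[C@H](c2ccccc2)C1` carries the change (amino in place of pyrrolidin-1-yl on a saturated chain carbon, two bonds along the chain from a saturated ring carbon). Within the data shown here, every measured compound bears a substituted nitrogen at the chain end; none bears a bare amino group, so no measured step covers this change. In this assay compound 4 is expected to give a weaker result than its parent, with a 14-fold higher number from compound 3 to compound 4 (1.14 log units; beyond the scatter) as the expected step, clearly beyond the scatter. Compound 4 is estimated at 50 nM, within a range from 12 nM to 250 nM.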

Compound 4, inhibition constant: 167 nM
Beside the measured number, compound 4's estimate is 3.3-fold (0.52 log units) below it; the measured number falls inside the stated range.
By their numbers in this assay, from the lowest: compound 3; then compound 1; then compound 4.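

Replacing pyrrolidin-1-yl with amino on a saturated chain carbon, two bonds along the chain from a saturated ring carbon, gives a 46-fold higher number from compound 3 to compound 4 (1.67 log units; beyond the scatter) in this assay. The earlier compounds shown here all bore a substituted nitrogen at the chain end, so they could not show what happens when every substituent on that nitrogen is removed; compound 4 shows that the bare amino group costs far more at this position than anything seen among them. This step also far exceeds the spread between repeats of a single compound in this assay: the several entries of compound 2 in this assay, 1.8 nM; 2.4 nM (2 entries)

The compounds shown leave open whether a methylamino group, carrying a single methyl on the nitrogen, would regain the lost ground. They also leave open how a piperidin-1-yl group or a longer chain would fare.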